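A few compounds are considered here, and "the series" means these few. Any claim that something is new, unique, unknown or untested is made for them only; others in the source may bear on it.

Compounds measured so far:
Compound 1 `COc1cc(/C=C/C(=O)c2cccc(-n3cc(-c4ccc(Cl)cc4)[nH]c3=O)c2)cc(OC)c1OC` gives 2400 nM in a functional assay on OVCAR-3 cells (Homo sapiens) for inhibition; a higher number here means a weaker inhibitor of growth, a lower number a stronger inhibitor of growth.
Compound 2 `COc1cc(/C=C/C(=O)c2cccc(-n3cc(-c4ccccc4)[nH]c3=O)c2)ccc1O` gives 2290 nM in this assay.
Compound 3 `O=C(/C=C/c1cccc(O)c1)c1cccc(-n2cc(-c3ccccc3)[nH]c2=O)c1` gives 3080 nM in this assay.

Among the compounds with values here, compound 3 sits within the scatter of both compound 1 and compound 2; the only single-point step recorded, a 1.3-fold higher number from compound 2 to compound 3 (0.13 log units; within the scatter), changed nothing beyond the scatter. Compound 4 `O=C(/C=C/c1cccc(O)c1)c1cccc(-n2cc(-c3ccc(Cl)cc3)[nH]c2=O)c1` differs from compound 3 by chloro in place of hydrogen on an aromatic carbon. Within the data shown here, no measured pair isolates this change: compound 1 carries the chloro group and compound 2 does not, but they also differ on the chain aryl, and their two values lie within the scatter of each other. Nothing in the data therefore points to a shift; the step of a 1.1-fold lower number from compound 3 to compound 4 (0.04 log units; within the scatter) is expected to stay within the scatter. Compound 4 is estimated at 2800 nM, between 1500 nM and 5500 nM.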

Compound 4, concentration for 50% growth inhibition: 1560 nM
Estimate against measurement, compound 4: 1.8-fold (0.25 log units) above; low and high end bracket the measured number.
By their numbers in this assay, from the lowest: compounds 4, 2, 1 and 3 (each within the scatter of the next).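

Within the data shown here, the first direct reading of phenyl to 4-chlorophenyl in this assay is a 2.0-fold lower number from compound 3 to compound 4 (0.30 log units; within the scatter) and stays within the scatter, so chloro in place of hydrogen at this place, para to a large group, is accommodated without a step beyond it. Among these compounds, this reading applies only with the 3-hydroxyphenyl group on the chain, as no other matched pair tests the change. No measurement available here bears on a reason for this reading.

Left open is how an amine or a carboxylic acid at this place would read in this assay.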